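Swapping sulfamoyl for methoxy on a naphthoquinone triazole

The source may report more compounds than this note shows. Statements on the series, on what has been measured and on what is new or still open speak of the compounds shown alone.

Of the compounds shown here, two that share a core have been tested so far. Compound 1 `CC(C)=CCC1=C(OCc2cn(C3CCN(C(=O)OC(C)(C)C)CC3)nn2)C(=O)c2ccccc2C1=O` and compound 2 `CC(C)=CCC1=C(OCc2cn(-c3ccc(S(N)(=O)=O)cc3)nn2)C(=O)c2ccccc2C1=O` differ in the group attached to the triazole ring. In an ADME assay on HepG2 cells (Homo sapiens) for cytotoxicity, read by MTT assay, with a stated time of 24 h (on this read-out lower numbers stand for higher toxicity in this test and higher numbers for lower toxicity in this test), compound 1 gives 136000 nM, and in this assay compound 2 gives 483000 nM. Among the compounds with values here, compound 2 thus stands at the highest of the two numbers, and its only neighbour, compound 1, sits at a lower number, a gap that lies beyond the usual scatter of this measurement. Within the data shown here, no pair of measured compounds differing in a single place is available, so no measured step can guide the next change.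

Compound 3 `COc1ccc(-n2cc(COC3=C(CC=C(C)C)C(=O)c4ccccc4C3=O)nn2)cc1` is the unmeasured compound. It differs from compound 2 in one place: methoxy in place of sulfamoyl on an aromatic carbon. Without a measured step of this kind, only a cautious expectation is possible. Compound 3 is expected to move by about a 1.9-fold lower number from compound 2 to compound 3 (0.29 log units; within the scatter) in this assay, a modest downward shift that may not exceed the scatter. Compound 3 is therefore estimated at 250000 nM in this assay, with a likely range from 100000 nM to 600000 nM.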

Compound 3, half-maximal cytotoxic concentration: 200000 nM
Estimate against measurement, compound 3: 1.3-fold (0.10 log units) above, and the stated range covers the measured number.
By their numbers in this assay, from the lowest: compounds 1 and 3 (each within the scatter of the next); then compound 2.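

In this assay, within the data shown here, replacing 4-sulfamoylphenyl with 4-methoxyphenyl gives a 2.4-fold lower number from compound 2 to compound 3 (0.38 log units; beyond the scatter), the first measured change at a single place, and it shows that the number responds to the group on this aromatic carbon. A lower number here stands for higher toxicity in this test, so compound 3 is the more toxic of this pair, although the step is modest and compound 3 still gives 200000 nM. No accompanying measurement bears on what lies behind this shift, so it remains an observation about these two compounds alone.

Among these compounds, with only one swap at this place, the step cannot show whether the shift comes from losing sulfamoyl, from gaining methoxy, or from both, and an amine or a carboxylic acid on the same aromatic carbon would test how far the number moves with other groups. As far as these compounds go, whether the same change would give a similar step with a different group on the other side of the triazole also remains open.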